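Working notes: from 3-fluorobenzyl to 2-bromobenzyl

This account rests on a few compounds, and the source may have more. Where it says the series, first, only, none or still open, it means among the compounds named here.

Measured so far in a functional assay on U-251 cells (Homo sapiens) for antiproliferative activity, read by MTT assay, with a stated time of 24 h; a lower number here means a stronger inhibitor, a higher number a weaker inhibitor:
- compound 1 `COc1cc(OC)c(-c2coc3cc(OCc4ccc(C#N)cc4)ccc3c2=O)cc1OC`: 6180 nM
- compound 2 `COc1cc(OC)c(-c2coc3cc(OCc4cccc(F)c4)ccc3c2=O)cc1OC`: 3510 nM

Compound 2 stands within the scatter of compound 1, so these two numbers give no ranking. Compound 3 `COc1cc(OC)c(-c2coc3cc(OCc4ccccc4Br)ccc3c2=O)cc1OC` keeps the shared core and differs from compound 2 only on a saturated chain carbon bound to an oxygen on an aromatic ring: 2-bromophenyl in place of 3-fluorophenyl on a saturated chain carbon bound to an oxygen on an aromatic ring. Cut one bond further out, the same difference reads 3-fluorobenzyl to 2-bromobenzyl.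

Among the measured compounds shown here, the one measured step at this place is a 1.8-fold lower number from compound 1 to compound 2 (0.25 log units; within the scatter). It replaced 4-cyanophenyl with 3-fluorophenyl. For the measured compounds named here, no measured compound carries 2-bromophenyl, so the data say nothing direct about that group, and a single step is thin evidence. Resting on that step and on compound 2 at 3510 nM, no step beyond the scatter is expected in this assay, and no direction can be called with any confidence. The expected step is a 1.1-fold higher number from compound 2 to compound 3 (0.03 log units; within the scatter). For compound 3 the estimate is 3800 nM, with an expected range from 1500 nM to 10000 nM.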

Compound 3, half-maximal inhibitory concentration: > 10000 nM
Compound 3: no number, only a limit (the forecaster's own chance of this, stated with the estimate: 8%); middle value at least 2.6-fold (0.42 log units) away from the limit.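

Among the compounds shown here, at the saturated chain carbon bound to an oxygen on an aromatic ring, the change from 3-fluorobenzyl to 2-bromobenzyl gives an at least 2.8-fold higher number from compound 2 to compound 3 (0.45 log units; beyond the scatter), the first step beyond the scatter, and so the first sign that the read-out in this assay responds to the group at this place. Measured against the 4-cyanophenyl group of compound 1, the same 2-bromophenyl group gives an at least 1.6-fold higher number from compound 1 to compound 3 (0.20 log units; that floor lies within the scatter), so this pair has no firm ranking. Compound 3 carries a limit of the assay and not a number, so the step from compound 2 has only a floor and its full size stays unknown: the limit of > 10000 nM in this assay, at which 1 of the 3 values shown sits.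

On these data alone, it remains open whether the change follows the bromine atom itself or its place on the ring, a question that a plain benzyl group or a chlorine-bearing benzyl group could help to settle. Also open, as far as these compounds go, is how an amine, a carboxylic acid or a longer chain at this place would read in this assay.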